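The source may hold more compounds than are shown below. What is called first, only, known or untested is meant among the compounds shown, and "the series" means these compounds.

Measured compounds in the series:
Compound 1 `C=C1CC[C@@H]2[C@](C)(COC(C)=O)[C@H](OC(C)=O)CC[C@@]2(C)[C@H]1CC(Nc1ccc(S(=O)(=O)Nc2ccc(Cl)nn2)cc1)C1=CCOC1=O`; in a functional assay on DU-145 cells (Homo sapiens) for inhibition, read by sulforhodamine B assay, with a stated time of 48 h (a higher number here means a weaker inhibitor of growth, a lower number a stronger inhibitor of growth), compound 1 gives 3450 nM.
Compound 2 `C=C1CC[C@@H]2[C@](C)(COC(C)=O)[C@H](OC(C)=O)CC[C@@]2(C)[C@H]1CC(Nc1ccc(S(=O)(=O)Nc2nccc(C)n2)cc1)C1=CCOC1=O`; in this assay compound 2 gives 11800 nM.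
Compound 3 `C=C1CC[C@@H]2[C@](C)(COC(C)=O)[C@H](OC(C)=O)CC[C@@]2(C)[C@H]1CC(Nc1ccc(S(=O)(=O)Nc2ncccn2)cc1)C1=CCOC1=O`; in this assay compound 3 gives 3070 nM.

Compound 2 holds the highest number of the three. The step of a 3.4-fold higher number from compound 1 to compound 2 (0.53 log units; beyond the scatter) and the step of a 3.8-fold lower number from compound 2 to compound 3 (0.58 log units; beyond the scatter) both lie beyond the scatter, while the step of a 1.1-fold lower number from compound 1 to compound 3 (0.05 log units; within the scatter) does not, so the two rings without a methyl sit close together and compound 2 stands apart from them.

Compound 4 `C=C1CC[C@@H]2[C@](C)(COC(C)=O)[C@H](OC(C)=O)CC[C@@]2(C)[C@H]1CC(Nc1ccc(S(=O)(=O)Nc2nccs2)cc1)C1=CCOC1=O` is the next member. The change is 1,3-thiazol-2-yl in place of 4-methylpyrimidin-2-yl on a sulfonamide nitrogen. Among the measured compounds shown here, two measured steps bear on this: the ring swap on the sulfonamide nitrogen a 3.4-fold higher number from compound 1 to compound 2 (0.53 log units; beyond the scatter) and the removal of the methyl a 3.8-fold lower number from compound 2 to compound 3 (0.58 log units; beyond the scatter). Both point the same way: leaving the 4-methylpyrimidin-2-yl ring has gone with a lower number, and a 1,3-thiazol-2-yl ring carries no methyl. A modest step downward is therefore expected, about a 3.4-fold lower number from compound 2 to compound 4 (0.53 log units; beyond the scatter). Compound 4 is estimated at 3500 nM in this assay, with a range of 1500 nM to 8500 nM.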

Compound 4, concentration for total growth inhibition: 15800 nM
Estimate against measurement, compound 4: 4.5-fold (0.65 log units) below; the measured number lies above the stated range.
By their numbers in this assay, from the lowest: compounds 3 and 1 (each within the scatter of the next); then compounds 2 and 4 (each within the scatter of the next).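

In this assay the 1,3-thiazol-2-yl ring on the sulfonamide nitrogen does not group with the other rings that lack a methyl: a 5.1-fold higher number from compound 3 to compound 4 (0.71 log units; beyond the scatter) and a 4.6-fold higher number from compound 1 to compound 4 (0.66 log units; beyond the scatter) both lie beyond the scatter, while a 1.3-fold higher number from compound 2 to compound 4 (0.13 log units; within the scatter) stays within it. Lack of a methyl is therefore not enough to give a low number at this position, since compound 4 has no methyl yet groups with methyl-bearing compound 2, and the earlier link between the methyl and the higher number holds only for the pair compound 2 and compound 3. Nothing measured here explains why these rings differ.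

Still open, going by these compounds, is whether a phenyl or 1,3-oxazol-2-yl ring on this nitrogen would group with compound 1 and compound 3 or with compound 2 and compound 4. On these data alone, how a methyl on the 1,3-thiazol-2-yl ring would shift the number is also open.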